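From compound 3 to compound 4: a side-chain swap

This account rests on a few compounds, and the source may have more. Where it says the series, first, only, none or still open, it means among the compounds named here.

In a functional assay for inhibition, with Homo sapiens as the target (on this read-out lower numbers stand for stronger inhibition and higher numbers for weaker inhibition), compound 1 `O=C(NC[C@H](NS(=O)(=O)c1ccccc1)C(=O)O)c1cc2cc(OCCC3CCNCC3)ccc2[nH]1` gives 8 nM and compound 2 `O=C(NC[C@H](NS(=O)(=O)c1ccccc1)C(=O)O)c1cc2ccc(OCC3CCNCC3)cc2[nH]1` gives 15 nM while compound 3 `Nc1cc(COc2ccc3[nH]c(C(=O)NC[C@H](NS(=O)(=O)c4ccccc4)C(=O)O)cc3c2)ccn1` gives 45 nM as the highest number of the three. Compound 3 is thus the weakest inhibitor measured so far.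

Compound 4 `O=C(NC[C@H](NS(=O)(=O)c1ccccc1)C(=O)O)c1cc2cc(OCCCc3c[nH]cn3)ccc2[nH]1` is still unmeasured. It carries 2-(1H-imidazol-4-yl)ethyl in place of 2-aminopyridin-4-yl on a saturated chain carbon bound to an oxygen on an aromatic ring.

Among the compounds with values here, only one measured step bears on this place: a 5.6-fold higher number from compound 1 to compound 3 (0.75 log units; beyond the scatter) when 2-aminopyridin-4-yl replaced (piperidin-4-yl)methyl. That step is modest but beyond the scatter, and it shows that this assay responds to changes here. Within the data shown here, no measured compound carries the new group, so the direction is uncertain. A modest step toward weaker inhibition is the cautious expectation, and the expected change is a 2.2-fold higher number from compound 3 to compound 4 (0.35 log units; beyond the scatter) in this assay for now. For compound 4 the estimated value is 100 nM with an expected range from 25 nM to 400 nM in this read-out.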

Compound 4, half-maximal inhibitory concentration: 100 nM
Compound 4: the middle estimate sits on the measured number at the digits printed, and the stated range covers the measured number.
By their numbers in this assay, from the lowest: compounds 1 and 2 (each within the scatter of the next); then compound 3; then compound 4.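

In this assay, moving from the six-membered aromatic ring of 2-aminopyridin-4-yl to the five-membered aromatic ring of 2-(1H-imidazol-4-yl)ethyl gives a 2.2-fold higher number from compound 3 to compound 4 (0.35 log units; beyond the scatter), even though both groups have the same heavy-atom count. Against the saturated ring of compound 1, the change to (1H-imidazol-4-yl)methyl gives a 13-fold higher number from compound 1 to compound 4 (1.10 log units; beyond the scatter), the largest step seen at this place, so both aromatic replacements shown here give higher numbers than the piperidin-4-yl series. No experimental evidence here explains these steps.

On these data alone, compound 4 changes both the ring and the chain length relative to compound 3, so their separate contributions remain unknown. As far as these compounds go, it is also open how an open-chain amine such as 3-aminopropyl would compare with these ring-bearing groups.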